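This account rests on a few compounds, and the source may have more. Where it says the series, first, only, none or still open, it means among the compounds named here.

In a functional assay on MOLT-4 cells (Homo sapiens) for inhibition, read by MTT assay, with a stated time of 72 h (on this read-out lower numbers stand for stronger inhibition and higher numbers for weaker inhibition), compound 1 `COc1cc(NC(C)CCCNC(=O)NNC(=O)Nc2cccc(F)c2)c2ncccc2c1` gives >= 250000 nM, which is a limit and not a number. Within the data shown here, compound 2 `COc1cc(NC(C)CCCNC(=O)NNC(=O)Nc2cccc(Cl)c2)c2ncccc2c1` gives 93000 nM, the only actual number so far. Compound 3 `COc1cc(NC(C)CCCNC(=O)NNC(=O)Nc2ccc(O)cc2)c2ncccc2c1` carries 4-hydroxyphenyl in place of 3-chlorophenyl on an amide-type nitrogen. Among the measured compounds shown here, the only measured step that bears on this is an at least 2.6-fold lower number from compound 1 to compound 2 (0.42 log units; beyond the scatter), for chloro in place of fluoro on an aromatic carbon. That step is only a partial guide, since it swaps one halogen for another, whereas compound 3 has no halogen on this ring at all. It still suggests that losing the chloro will move the number up in this assay. A modest change towards weaker inhibition is therefore expected, given as an estimated 1.4-fold higher number from compound 2 to compound 3 (0.15 log units; within the scatter). Compound 3 is expected at 130000 nM, with an estimated range of 40000 nM to 250000 nM.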

Compound 3, half-maximal inhibitory concentration: 104000 nM
For compound 3 the middle estimate is 1.3-fold (0.10 log units) above the measured one, and the stated range covers the measured number.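

In this assay, putting 4-hydroxyphenyl in place of 3-chlorophenyl on the amide-type nitrogen gives a 1.1-fold higher number from compound 2 to compound 3 (0.05 log units; within the scatter), so a halogen on this ring is not required to keep the level seen with compound 2. The 3-fluorophenyl group of compound 1 now stands apart from a second, non-halogen group as well, with an at least 2.4-fold lower number from compound 1 to compound 3 (0.38 log units; beyond the scatter), so a change at this position does not simply follow the presence or absence of a halogen. The true size of that step remains unknown, as compound 1 is read only as a limit: the limit of >= 250000 nM in this assay, at which 1 of the 3 values shown sits.

The change from 3-chlorophenyl to 4-hydroxyphenyl alters both the substituent and its place on the ring, and the compounds shown do not separate the two. From the compounds shown here alone, whether 3-hydroxyphenyl, 4-chlorophenyl, or an aminophenyl or carboxyphenyl group would read the same remains open.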